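Cyclohexyl for pyridin-3-yl: a cytotoxicity estimate

A few compounds are considered here, and "the series" means these few. Any claim that something is new, unique, unknown or untested is made for them only; others in the source may bear on it.

Measured so far in an ADME assay on HepG2 cells (Homo sapiens) for cytotoxicity, read by fluorescence and resazurin assay, with a stated time of 24 h; on this read-out higher numbers stand for lower toxicity in this test and lower numbers for higher toxicity in this test:
- compound 1 `COC(=O)c1ccc(-c2nnc(SC3=CS(=O)(=O)c4ccccc43)o2)cc1` gives 18000 nM
- compound 2 `O=S1(=O)C=C(Sc2nnc(-c3cccnc3)o2)c2ccccc21` gives 14000 nM
- compound 3 `CC(=O)Nc1ccc(-c2nnc(SC3=CS(=O)(=O)c4ccccc43)o2)cc1` gives 31000 nM

Compound 2 has the lowest of the three numbers in this assay. Its nearest neighbour is compound 1, which lies within the scatter, while compound 3 stands further away, beyond the scatter. Within the data shown here, the one step that can be read between measured compounds runs a 1.7-fold higher number from compound 1 to compound 3 (0.24 log units; within the scatter); it exchanges groups on a benzene ring attached to the shared core and is within the scatter.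

Compound 4 `O=S1(=O)C=C(Sc2nnc(C3CCCCC3)o2)c2ccccc21` has not been measured. It differs from compound 2 by cyclohexyl in place of pyridin-3-yl on an aromatic carbon. Among the measured compounds shown here, no measured step involves this kind of exchange, so nothing among the measured compounds speaks for or against a shift. For the measured compounds named here, the only comparable step, from compound 1 to compound 3, stayed within the scatter. Compound 4 is therefore expected to stay close to compound 2 in this assay, with a step of no change at the digits printed from compound 2 to compound 4 (within the scatter). The estimate for compound 4 is 14000 nM, expected to fall between 6000 nM and 32000 nM.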

Compound 4, half-maximal cytotoxic concentration: 15000 nM
The estimate for compound 4 lay 1.1-fold (0.03 log units) below the measured number, within the range that was stated.
By their numbers in this assay, from the lowest: compounds 2, 4, 1 and 3 (each within the scatter of the next, the first and the last beyond it).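

In this assay, cyclohexyl in place of pyridin-3-yl gives a 1.1-fold higher number from compound 2 to compound 4 (0.03 log units; within the scatter) on the five-membered aromatic ring of the shared core. The earlier step changed a group on a benzene ring further out, whereas this one changes the ring attached directly at this position. Replacing an aromatic ring that has a ring nitrogen and a hydrogen-bond acceptor with a non-aromatic ring of carbon only leaves the two numbers within the scatter, and nothing measured here gives a reason for that.

Going by these compounds, all four compounds carry a six-membered ring at this position, so the effect of an amine, a carboxylic acid or an open alkyl chain there remains open. On these data alone, whether a smaller ring, such as cyclopropyl, would match these numbers also remains open.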